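The source may report more compounds than this note shows. Statements on the series, on what has been measured and on what is new or still open speak of the compounds shown alone.

Of the compounds shown here, three of a shared core have been measured in a functional assay on SAOS-2 cells (Homo sapiens) for antiproliferative activity, read by MTT assay, with a stated time of 72 h; a higher number here means a weaker inhibitor, a lower number a stronger inhibitor. Compound 1 `CCCCCOC1=C(C(=O)c2ccccc2)C(c2ccc(Br)cc2)N(CCCn2ccnc2)C1=O` gives 9990 nM. Compound 2 `Cc1ccc(NC2=C(C(=O)c3ccccc3)C(c3ccc(Br)cc3)N(CCCn3ccnc3)C2=O)cc1` gives 31900 nM, and compound 3 `CCOc1ccc(NC2=C(C(=O)c3ccccc3)C(c3ccc(Br)cc3)N(CCCn3ccnc3)C2=O)cc1` gives 30900 nM. The replacement of pentyloxy by an arylamino group shows up as a 3.2-fold higher number from compound 1 to compound 2 (0.50 log units; beyond the scatter) and a 3.1-fold higher number from compound 1 to compound 3 (0.49 log units; beyond the scatter), whereas the exchange within the arylamino series is only a 1.0-fold lower number from compound 2 to compound 3 (0.01 log units; within the scatter). Compound 3 thus sits with compound 2 at the weaker end of these three numbers, apart from compound 1.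

Compound 4 `O=C(C1=C(Nc2ccc(OC(F)(F)F)cc2)C(=O)N(CCCn2ccnc2)C1c1ccc(Br)cc1)c1ccccc1` carries one further change: trifluoromethyl in place of ethyl on an oxygen on an aromatic ring. For the measured compounds named here, the only measured step that touches the same position, a 1.0-fold lower number from compound 2 to compound 3 (0.01 log units; within the scatter), is flat, so a swap of one small group for another at that point has not moved this assay before. Going by the values given here, no measured step involves a fluorinated group, so the expectation rests on that single comparison. For compound 4 the expected step is a 1.0-fold lower number from compound 3 to compound 4 (0.01 log units; within the scatter), meaning no movement beyond the scatter. Compound 4 is therefore estimated at 30000 nM, within a range from 12000 nM to 75000 nM.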

Compound 4, half-maximal inhibitory concentration: 17900 nM
Beside the measured number, compound 4's estimate is 1.7-fold (0.22 log units) above it; low and high end bracket the measured number.
By their numbers in this assay, from the lowest: compounds 1, 4, 3 and 2 (each within the scatter of the next, the first and the last beyond it).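

In this assay, for the compounds shown here, trifluoromethyl in place of ethyl on the oxygen gives a 1.7-fold lower number from compound 3 to compound 4 (0.24 log units; within the scatter) and stays level with the ethoxy compound, while trifluoromethoxy in place of methyl gives a 1.8-fold lower number from compound 2 to compound 4 (0.25 log units; within the scatter) and likewise stays level, so the first fluorinated group at this position still leaves the arylamino compounds unseparated. The new point is a 1.8-fold higher number from compound 1 to compound 4 (0.25 log units; within the scatter) even though compound 2 and compound 3 each lie beyond the scatter from compound 1, so the gap between arylamino and pentyloxy no longer holds for every arylamino compound. No measurement here offers an explanation for these numbers.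

Going by these compounds, it stays open whether an amine or a carboxylic acid in place of trifluoromethoxy would move this assay beyond the scatter. A longer chain in place of pentyloxy also remains untested among the compounds shown.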